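A ring methyl added to compound 2

This account rests on a few compounds, and the source may have more. Where it says the series, first, only, none or still open, it means among the compounds named here.

Compound 1 `CCOC(=O)N(C)CC#CCn1cncc1C`: > 100 mg/kg (a limit)
Compound 2 `CN(C)C(=O)N(C)CC#CCn1ccnc1`: 25.4 mg/kg

In a functional assay on the whole organism for agonist activity, with Mus musculus as the target (a lower number here means that less compound is needed, a higher number that more compound is needed for the effect), compound 1 gives > 100 mg/kg, which is a limit of the assay and not a number. Among the measured compounds shown here, compound 2 gives 25.4 mg/kg, the only actual number so far, so it has no numerical value to be ranked against.

Compound 3 `Cc1cncn1CC#CCN(C)C(=O)N(C)C` departs from compound 2 in one place: methyl in place of hydrogen on an aromatic carbon. For the measured compounds named here, no measured pair shows this change alone. Compound 1 also carries this ring methyl and reached only its limit of > 100 mg/kg, so a higher dose is expected, though with little certainty. The estimated change is a 1.8-fold higher number from compound 2 to compound 3 (0.25 log units; within the scatter), and it may not clearly exceed the scatter. For compound 3, the expected value in this assay is 45 mg/kg, with an estimated range of 12 mg/kg to 150 mg/kg.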

Compound 3, dose for half-maximal effect: > 100 mg/kg
Compound 3 was reported as a limit; the forecaster's own chance of this, stated with the estimate: 30%; middle value at least 2.2-fold (0.34 log units) from the limit.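

Methyl in place of hydrogen on an aromatic carbon, next to the ring atom that bears a large group, can now be read alone, and in this assay this change gives an at least 3.9-fold higher number from compound 2 to compound 3 (0.59 log units; beyond the scatter). Compound 3 gives > 100 mg/kg, which is a limit of the assay and not a number, so this step marks only the smallest size the change can have. The step between compound 1 and compound 3 cannot be read, as both values are limits, and the exchange of ethoxy for dimethylamino on the carbonyl carbon therefore remains unresolved.

Going by these compounds, it remains open whether a chlorine or an ethyl group at this position would raise the required dose as well. On these data alone, it is equally open whether the ethoxy carbonyl compound would give a measurable dose with hydrogen in place of the ring methyl.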